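Ring-closed side chain on two purine cores in L1210

The source may hold more compounds than are shown below. What is called first, only, known or untested is meant among the compounds shown, and "the series" means these compounds.

Compound 1 `Nc1ncnc2c1ncn2CC#CCO` carries an open 4-hydroxybut-2-yn-1-yl chain on the aromatic nitrogen; in a functional assay on L1210 cells (Mus musculus) for inhibition (a higher number here means a weaker inhibitor, a lower number a stronger inhibitor), compound 1 gives 490000 nM. Compound 2 `Nc1nc(O)c2ncn(CC#CCO)c2n1` bears the same chain on a second core; the difference between the two cores is not broken down here. In this assay compound 2 gives 210000 nM, the lower of the two numbers and beyond the scatter of compound 1. Compound 3 `Nc1ncnc2c1ncn2C1C=CCO1` replaces the chain of compound 1 (a group of 5 heavy atoms (4 carbon, 1 oxygen; one five-membered non-aromatic ring with 1 hetero atom) in place of a group of 5 heavy atoms (4 carbon, 1 oxygen; no ring), on an aromatic nitrogen). For compound 3 in this assay only a limit is reported, > 500000 nM. The step of an at least 1.0-fold higher number from compound 1 to compound 3 (0.00 log units; that floor lies within the scatter) therefore has a floor but no measured size, since the limit of > 500000 nM in this assay, at which 1 of the 3 values shown sits, caps it.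

Compound 4 `Nc1nc(O)c2ncn(C3C=CCO3)c2n1` applies the same change to compound 2 (a group of 5 heavy atoms (4 carbon, 1 oxygen; one five-membered non-aromatic ring with 1 hetero atom) in place of a group of 5 heavy atoms (4 carbon, 1 oxygen; no ring), on an aromatic nitrogen); the place lines agree word for word. Given that the earlier step of an at least 1.0-fold higher number from compound 1 to compound 3 (0.00 log units; that floor lies within the scatter) moved toward weaker inhibition only by an unresolved floor, the step to compound 4 is expected to be similar, a 1.9-fold higher number from compound 2 to compound 4 (0.28 log units; within the scatter). Compound 4 is accordingly estimated at 400000 nM in this assay, with a range from 150000 nM to 1000000 nM, and a fair chance that only a limit is returned.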

Compound 4, half-maximal inhibitory concentration: > 350000 nM
Compound 4: no number, only a limit; the forecaster's own chance of this, stated with the estimate: 45%; the middle value lies beyond the limit too.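

In this assay compound 4 gives > 350000 nM as a limit of the assay, not a number. The replacement of the 4-hydroxybut-2-yn-1-yl chain by the ring on this core therefore reads only as an at least 1.6-fold higher number from compound 2 to compound 4 (0.22 log units; that floor lies within the scatter) and has a floor but no measured size. Neither core gives a measured number after the change, so the series does not show that the change carries over from one core to the other with the same size, nor that its size differs: the same change on two cores in this assay, an at least 1.0-fold higher number (0.00 log units; that floor lies within the scatter) from compound 1 to compound 3 and an at least 1.6-fold higher number (0.22 log units; that floor lies within the scatter) from compound 2 to compound 4; the limit leaves it open whether they differ.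

From the compounds shown here alone, the size of the change on either core stays open, since the true readings of compound 3 and compound 4 are unknown. Also open, going by these compounds, is how a longer chain, or an amine or a carboxylic acid in place of the hydroxyl of the open chain, would read on the same aromatic nitrogen in this assay on these two cores.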